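The compounds below may be only part of what the source reports. "The series", "measured", "known", "first", "only" and "open" are said of these compounds alone.

Measured compounds in a functional assay on JAR cells (Homo sapiens) for inhibition, read by MTT assay, with a stated time of 72 h, tested at 10 uM; on this read-out higher numbers stand for more inhibition at the one concentration tested (going by the name of the read-out) and lower numbers for less inhibition:
compound 1 `CCOC(=O)C1=C(Nc2ccccc2)S/C(=C\c2cccc(C(=O)O)c2)C1=O`, 50.6%;
compound 2 `CCOC(=O)C1=C(Nc2cccc(F)c2)S/C(=C\c2ccc[nH]2)C1=O`, 45.4%;
compound 3 `CCOC(=O)C1=C(Nc2cccc([N+](=O)[O-])c2)S/C(=C\c2ccc[nH]2)C1=O`, 57.4%.

Compound 1 stands second highest of the three numbers; its gap to compound 2 and its gap to compound 3 both lie within the scatter, so no ordering among them is claimed. Among the measured compounds shown here, the one step that exceeds the scatter, a number 12 percentage points higher from compound 2 to compound 3 (beyond the scatter), concerns the aromatic carbon of the aniline side and not the position changed here.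

Compound 4 `CCOC(=O)C1=C(Nc2ccccc2)S/C(=C\c2cc3ccncc3[nH]2)C1=O` differs from compound 1 as follows: a group of 9 heavy atoms (7 carbon, 2 nitrogen; one five-membered aromatic ring with 1 hetero atom, one six-membered aromatic ring with 1 hetero atom) in place of a group of 9 heavy atoms (7 carbon, 2 oxygen; one six-membered aromatic ring of carbon only), on a double-bonded chain carbon bound to a double-bonded ring carbon. For the measured compounds named here, no measured pair bears on this exchange; compounds 2 and 3 carry a different group at that carbon but also a different aniline. With no guidance, the step is expected to stay within the scatter: a number 0.6 percentage points lower from compound 1 to compound 4 (within the scatter). Compound 4 is therefore estimated at 50%, with a range from 33% to 67%.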

Compound 4, a percentage reported as inhibition, at one concentration (the size of the read-out at that concentration, not a potency): 26.3%
Compound 4: the middle estimate sits 23.7 percentage points above what was measured, outside the stated range (below it).
By their numbers in this assay, from the lowest: compound 4; then compounds 2, 1 and 3 (each within the scatter of the next, the first and the last beyond it).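

In this assay, this position is sensitive to the group it carries: 3-carboxyphenyl giving way to the group with one five-membered and one six-membered aromatic ring produces a number 24.3 percentage points lower from compound 1 to compound 4 (beyond the scatter). The step arises although both groups count the same heavy atoms, hydrogen-bond donors and hydrogen-bond acceptors. No available measurement explains it.

As far as these compounds go, it remains open whether the step reflects the loss of 3-carboxyphenyl or the arrival of the new group. An unsubstituted phenyl or a 3-aminophenyl group at this carbon, on the same core, would help separate the two.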